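The compounds below may be only part of what the source reports. "The series", "measured", "known", "first", "only" and "open" are said of these compounds alone.

Compound 1: `Cc1ccc(S(=O)(=O)Nc2ccc(Br)c3ccccc23)cc1` — 27400 nM
Compound 2: `Cc1ccc(S(=O)(=O)Nc2cc(Oc3cc(F)cc(F)c3)cc3cccnc23)cc1` — 80 nM

Of the compounds shown here, two have been measured in a functional assay on HT-1080 cells (Homo sapiens) for antiproliferative activity, with a stated time of 6 days; a lower number here means a stronger inhibitor of growth, a higher number a weaker inhibitor of growth. Compound 1, with the structure `Cc1ccc(S(=O)(=O)Nc2ccc(Br)c3ccccc23)cc1`, gives 27400 nM in this assay. Compound 2, with the structure `Cc1ccc(S(=O)(=O)Nc2cc(Oc3cc(F)cc(F)c3)cc3cccnc23)cc1`, gives 80 nM in this assay. Compound 2 therefore stands with the lower of the two numbers, and the gap between the two values is wide enough to lie beyond the usual scatter of repeated measurements. The two structures differ in several places at once, so no single change can be credited with that gap.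

Compound 3, with the structure `Cc1ccc(S(=O)(=O)Nc2cc(Oc3cccc(C#N)c3)cc3cccnc23)cc1`, has not yet been measured. It differs from compound 2 in one place: 3-cyanophenyl in place of 3,5-difluorophenyl on an oxygen on an aromatic ring. Going by the values given here, no measured pair shows what this change does in this assay, so there is no step to lean on. The step expected here is a 1.5-fold higher number from compound 2 to compound 3 (0.18 log units; within the scatter), which would not clearly lie beyond the scatter. Compound 3 is therefore estimated at 120 nM in this assay, with a likely range from 30 nM to 500 nM.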

Compound 3, concentration for 50% growth inhibition: 6830 nM
The estimate for compound 3 lay 57-fold (1.76 log units) below the measured number, outside the stated range (above it).
By their numbers in this assay, from the lowest: compound 2; then compound 3; then compound 1.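

Going by these compounds alone, this is the first comparison that changes only one place, and in this assay it shows that the group on the oxygen is far from interchangeable: the swap gives an 85-fold higher number from compound 2 to compound 3 (1.93 log units; beyond the scatter), a large move for a single change. The two groups match in size by count, with 8 heavy atoms each and one six-membered aromatic ring of carbon only, so neither that count nor the ring alone sets the number at this position; they differ in two fluorines on one side and a nitrile on the other, which adds a triple bond and a hydrogen-bond acceptor. Nothing at hand accounts for a step of this size, so it stands as an observation without a stated cause.

This single swap removes the fluorines and adds the nitrile at once, so it leaves open which of the two matters more. A plain phenyl or a 3-fluorophenyl on the same oxygen would help to separate them, and a 3-aminophenyl would show how a ring carrying an amine fares at this position.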